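The compounds below may be only part of what the source reports. "The series", "measured", "known", "first", "only" and "open" are said of these compounds alone.

Compound 1 `O=C(COc1cccc2ccc(N3CCCC3)nc12)NCc1ccccc1`. In an ADME assay on HEK-293T cells (Homo sapiens) for cytotoxicity, read by CCK-8 assay, with a stated time of 48 h (a lower number here means a stronger inhibitor, a higher number a weaker inhibitor), compound 1 gives > 100000 nM, which is a limit of the assay.
Compound 2 `CN1CCN(c2ccc3cccc(OCC(=O)NCc4ccccc4)c3n2)CC1`. In this assay compound 2 gives > 100000 nM, again a limit of the assay.
Compound 3 `CC(C)(C)OC(=O)N1CCN(c2ccc3cccc(OCC(=O)NCc4ccccc4)c3n2)CC1`. In this assay compound 3 gives > 100000 nM, also a limit of the assay.

Compound 2 therefore stands at the assay limit, where every value shown sits (the limit of > 100000 nM in this assay, at which 3 of the 3 values shown sit). The unmeasured compound 4 `CN(C)c1ccc2cccc(OCC(=O)NCc3ccccc3)c2n1` differs from compound 2 by dimethylamino in place of 4-methylpiperazin-1-yl on an aromatic carbon. Going by the values given here, two measured steps bear on this change: a step that the two limits leave unreadable from compound 1 to compound 2 and a step that the two limits leave unreadable from compound 2 to compound 3; both are unreadable, since each joins two limits. No substituent on this aromatic carbon has yet produced a readable number in this assay. Compound 4 is expected to behave likewise, and the step that the limit leaves unreadable from compound 2 to compound 4 is estimated as none beyond the scatter. Compound 4 is estimated at 150000 nM, within 100000 nM to 300000 nM, most likely reported as a limit again.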

Compound 4, half-maximal inhibitory concentration: > 100000 nM
Compound 4 was reported as a limit (the forecaster's own chance of this, stated with the estimate: 85%); the middle value lies beyond the limit too.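

Compound 4 gives > 100000 nM in this assay, a limit of the assay. Its steps from compound 1 and from compound 2 join two limits and cannot be read. The compounds shown leave open whether any substituent on this aromatic carbon gives a readable number in this assay.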